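Opening the Ring: From Cyclopentyl to Hydroxybutylamino

This account rests on a few compounds, and the source may have more. Where it says the series, first, only, none or still open, it means among the compounds named here.

Within the data shown here, compound 2 `COc1cnc(-c2ccccn2)nc1C1CCCC1` gives 1800 nM in a functional assay on RAW264.7 cells (Mus musculus), with a stated time of 3 days (a higher number here means a weaker inhibitor, a lower number a stronger inhibitor), the highest of the two numbers known so far. Among the measured compounds shown here, its only measured neighbour is compound 1 `COc1cnc(-c2ccccn2)nc1N1CCCC1`, which in this assay gives 150 nM; the single recorded step, a 12-fold higher number from compound 1 to compound 2 (1.08 log units; beyond the scatter), is large and well beyond the scatter. Compound 3 `COc1cnc(-c2ccccn2)nc1NCCCCO` is the next compound in line: (4-hydroxybutyl)amino in place of cyclopentyl on an aromatic carbon.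

For the measured compounds named here, only that one step bears on the change now made. Going by the values given here, the group entering compound 3 shares with the pyrrolidin-1-yl of compound 1 an attachment to the ring through nitrogen, while the cyclopentyl of compound 2 is attached through carbon, and the one step that swaps such groups, a 12-fold higher number from compound 1 to compound 2 (1.08 log units; beyond the scatter), was large. He therefore expects compound 3 to move back toward compound 1, with a step of roughly a 6.0-fold lower number from compound 2 to compound 3 (0.78 log units; beyond the scatter), while allowing that the open chain may not recover all of what the ring gave. His estimate for compound 3 in this assay is 300 nM, within a range from 80 nM to 1200 nM.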

Compound 3, half-maximal inhibitory concentration: 3000 nM
The estimate for compound 3 lay 10-fold (1.00 log units) below the measured number; the whole stated range lies below it.
By their numbers in this assay, from the lowest: compound 1; then compounds 2 and 3 (each within the scatter of the next).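

In this assay, attachment through nitrogen alone does not restore the lower number: the (4-hydroxybutyl)amino group is bound to the aromatic carbon through nitrogen, as pyrrolidin-1-yl is, yet the change between those two groups is a 20-fold higher number from compound 1 to compound 3 (1.30 log units; beyond the scatter). Exchanging cyclopentyl for the open chain gives a 1.7-fold higher number from compound 2 to compound 3 (0.22 log units; within the scatter), so at this position the carbon-linked ring and the nitrogen-linked chain cannot be told apart in this measurement. The large step seen earlier therefore cannot be read as a simple matter of the linking atom, since among the three groups only pyrrolidin-1-yl stands apart, and nothing available explains why the open chain fails to match it.

The compounds shown leave open whether the difference from pyrrolidin-1-yl follows from opening the ring or from the terminal hydroxyl, as the chain changes in both respects at once. A plain butylamino chain would bear on the hydroxyl, while piperidin-1-yl or morpholin-4-yl would show how far the nitrogen-linked ring itself can be varied at this position.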